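Notes on the E-to-Z step in the acetylated pair

The source may report more compounds than this note shows. Statements on the series, on what has been measured and on what is new or still open speak of the compounds shown alone.

Compound 1 `CC(C)CC(=O)O[C@@H]1OC=C(CO[C@@H]2O[C@H](CO)[C@@H](O)[C@H](O)[C@H]2OC(=O)/C=C/c2ccc(O)cc2)[C@H]2CC[C@](O)(CO)[C@@H]12` is the parent measured in a functional assay on SK-MEL-2 cells (Homo sapiens) for cytotoxicity, read by sulforhodamine B assay, with a stated time of 48 h; on this read-out lower numbers stand for stronger inhibition and higher numbers for weaker inhibition. In this assay compound 1 gives > 10000 nM, which is a limit of the assay and not a number. Compound 2 `CC(C)CC(=O)O[C@@H]1OC=C(CO[C@@H]2O[C@H](CO)[C@@H](O)[C@H](O)[C@H]2OC(=O)/C=C\c2ccc(O)cc2)[C@H]2CC[C@](O)(CO)[C@@H]12` shares all atoms and bonds with compound 1 and differs only in configuration as drawn, one double bond being E in compound 1 and Z in compound 2. In this assay compound 2 gives 8400 nM. The step of an at least 1.1-fold lower number from compound 1 to compound 2 (0.07 log units; that floor lies within the scatter) is not readable as a real change. Relative to compound 1, compound 3 `CC(=O)OC[C@@]1(O)CC[C@@H]2C(CO[C@@H]3O[C@H](CO)[C@@H](O)[C@H](O)[C@H]3OC(=O)/C=C/c3ccc(O)cc3)=CO[C@@H](OC(=O)CC(C)C)[C@@H]21` carries acetyl in place of hydrogen on an oxygen on a saturated carbon. In this assay compound 3 gives > 10000 nM, again a limit of the assay and not a number. The step that the two limits leave unreadable from compound 1 to compound 3 cannot be sized because of the limit of > 10000 nM in this assay, at which 2 of the 3 values shown sit. Compound 3 thus sits at the limit, with no number of its own.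

Compound 4 `CC(=O)OC[C@@]1(O)CC[C@@H]2C(CO[C@@H]3O[C@H](CO)[C@@H](O)[C@H](O)[C@H]3OC(=O)/C=C\c3ccc(O)cc3)=CO[C@@H](OC(=O)CC(C)C)[C@@H]21` is the unmeasured partner: the two compounds have the same atoms and bonds and differ only in configuration as drawn: 1 of 10 stereo elements differ; a double bond is drawn E in compound 3 and Z in compound 4. For the measured compounds named here, the only measured step of the same kind, an at least 1.1-fold lower number from compound 1 to compound 2 (0.07 log units; that floor lies within the scatter), stayed within the scatter, so no step beyond the scatter is expected in this assay here either. For compound 4 the estimate is 9500 nM with a range from 5000 nM to 20000 nM. The expected step is an at least 1.0-fold lower number from compound 3 to compound 4 (0.02 log units; that floor lies within the scatter). A limit rather than a number remains quite likely.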

Compound 4, half-maximal inhibitory concentration: 5200 nM
Compound 4: middle estimate off by 1.8-fold (0.26 log units), on the high side; low and high end bracket the measured number.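

The E-to-Z change on the acetylated pair in this assay reads as an at least 1.9-fold lower number from compound 3 to compound 4 (0.28 log units; that floor lies within the scatter), so both Z compounds, compound 2 and compound 4, carry numbers while both E compounds, compound 1 and compound 3, sit at a limit, though neither E-to-Z step is printed as beyond the scatter. The acetyl change also gains its first readable size, on the Z pair, as a 1.6-fold lower number from compound 2 to compound 4 (0.21 log units; within the scatter), so acetyl in place of hydrogen on this oxygen shows no step beyond the scatter. On the E pair, the step from compound 1 to compound 3 still cannot be read: the limit of > 10000 nM in this assay, at which 2 of the 4 values shown sit.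

Going by these compounds, how far the E and Z forms truly lie apart remains open. Also open, on these data alone, is whether a longer acyl chain such as butanoyl, or a carboxylic acid, on this oxygen would give a step beyond the scatter.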